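The compounds below may be only part of what the source reports. "The series", "measured", "known", "first", "only" and "open" are said of these compounds alone.

The compounds measured so far:
- compound 1, `CCCCc1ccc(-c2cc3cn([C@H]4C[C@H](O)[C@@H](CO)O4)c(=O)nc3s2)cc1`, which in a functional assay on HeLa cells (Homo sapiens) for cytotoxicity, read by microscopy (on this read-out lower numbers stand for higher toxicity in this test and higher numbers for lower toxicity in this test), gives 50000 nM
- compound 2, `CCc1ccc(-c2cc3cn([C@H]4C[C@H](O)[C@@H](CO)O4)c(=O)nc3s2)cc1`, for which this assay reports only a limit, > 200000 nM
- compound 3, `CCCCCCCc1ccc(-c2cc3cn([C@H]4C[C@H](O)[C@@H](CO)O4)c(=O)nc3s2)cc1`, which in this assay gives 50000 nM

Compound 3 stands level with compound 1 in this assay: the step of no change at the digits printed from compound 1 to compound 3 (within the scatter) lies within the scatter. Compound 2 sits at the limit of the assay (the limit of > 200000 nM in this assay, at which 1 of the 3 values shown sits), so its distance from compound 3 is known only as a lower bound.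

Compound 4, `CCCc1ccc(-c2cc3cn([C@H]4C[C@H](O)[C@@H](CO)O4)c(=O)nc3s2)cc1`, differs from compound 3 by hydrogen in place of butyl on a saturated chain carbon, three bonds along the chain from an aromatic carbon. Among the measured compounds shown here, two measured steps bear on this change. Shortening the chain from compound 1 to compound 2 gave an at least 4.0-fold higher number from compound 1 to compound 2 (0.60 log units; beyond the scatter), a rise to the limit. Lengthening it from compound 2 to compound 3 gave an at least 4.0-fold lower number from compound 2 to compound 3 (0.60 log units; beyond the scatter). The change from compound 3 to compound 4 is shorter than either of those, and sits between them: compound 4 carries a chain shorter than compound 1 but longer than compound 2.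

Compound 4 is therefore expected to show a rise in this assay of a 2.0-fold higher number from compound 3 to compound 4 (0.30 log units; within the scatter), toward but not necessarily reaching the limit seen for compound 2. The estimate for compound 4 is 100000 nM, with a range from 50000 nM to 200000 nM.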

Compound 4, minimum cytotoxic concentration: 80000 nM
Estimate against measurement, compound 4: 1.3-fold (0.10 log units) above, within the range that was stated.
By their numbers in this assay, from the lowest: compounds 1, 3 and 4 (each within the scatter of the next). At a limit, above all of these: compound 2.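

In this assay, the propyl chain of compound 4 cannot be told apart from the longer chains: a 1.6-fold higher number from compound 3 to compound 4 (0.20 log units; within the scatter) and a 1.6-fold higher number from compound 1 to compound 4 (0.20 log units; within the scatter). The step beyond the scatter can now be narrowed to a single methyl on the saturated chain carbon, two bonds along the chain from an aromatic carbon, with an at least 2.5-fold lower number from compound 2 to compound 4 (0.39 log units; beyond the scatter), so among the four chains shown only the ethyl of compound 2 stands apart, where the earlier compounds showed only that a gap lay somewhere below butyl. Compound 2 is reported only as a limit, so this step gives a lower bound on the gap and not its size: the limit of > 200000 nM in this assay, at which 1 of the 4 values shown sits.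

As far as these compounds go, whether the number keeps its level with a chain longer than heptyl, or with a branched chain such as isobutyl or tert-butyl at this place, stays open. So does the effect of a hydroxyl, an ether oxygen, an amine or a carboxylic acid on the chain, since every chain shown here is a plain straight alkyl chain.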